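Pyridin-3-yl Replacing a Methylpyrazolyl on the Benzamide Core

A few compounds are considered here, and "the series" means these few. Any claim that something is new, unique, unknown or untested is made for them only; others in the source may bear on it.

Measured so far:
Compound 1, `CNC(=O)N1CCCc2ccc(NC(=O)c3ccc(-c4ccn(C)n4)cc3)cc21` — 830 nM
Compound 2, `CNC(=O)N1CCCc2ccc(NC(=O)c3cccc(-c4cnn(C)c4)c3)cc21` — 1040 nM

Both compounds were tested in a functional assay on MV4-11 cells (Homo sapiens) for antiproliferative activity, with a stated time of 6 days; a higher number here means a weaker inhibitor, a lower number a stronger inhibitor. Compound 1 gives 830 nM and compound 2 gives 1040 nM; the two values lie within the scatter of one another, so neither can be called the stronger inhibitor. Compound 1 holds the lower of the two numbers, and the gap to compound 2 is well inside the usual spread of repeated measurements.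

Compound 3, `CNC(=O)N1CCCc2ccc(NC(=O)c3ccc(-c4cccnc4)cc3)cc21`, has not yet been measured. It differs from compound 1 at a single position: pyridin-3-yl in place of 1-methyl-1H-pyrazol-3-yl on an aromatic carbon. Within the data shown here, no step between two measured compounds shows what such an exchange does on this core, so the direction cannot be taken from the data; the two measured compounds, which differ in the identity and attachment of the five-membered ring, give numbers within the scatter of each other. On that basis compound 3 is expected to stay close to compound 1, with a step of a 1.1-fold higher number from compound 1 to compound 3 (0.04 log units; within the scatter) that is not beyond the scatter. For compound 3 the estimated value in this assay is 900 nM, with a range from 400 nM to 2000 nM.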

Compound 3, half-maximal inhibitory concentration: 1160 nM
Estimate against measurement, compound 3: 1.3-fold (0.11 log units) below, and the stated range covers the measured number.
By their numbers in this assay, from the lowest: compounds 1, 2 and 3 (each within the scatter of the next).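

In this assay, putting pyridin-3-yl in place of 1-methyl-1H-pyrazol-3-yl on an aromatic carbon of a six-membered aromatic ring of carbon only, para to a large group, gives a 1.4-fold higher number from compound 1 to compound 3 (0.15 log units; within the scatter) on the shared core, and this is the one step shown that isolates a single place. The exchange sets a five-membered aromatic ring with 2 hetero atoms against a six-membered aromatic ring with 1 hetero atom at the same heavy-atom count, and this read-out does not tell the two groups apart at this position. Nothing available explains why the two groups read alike.

Going by these compounds, both groups seen at this place are aromatic rings, so it remains open whether a saturated ring such as morpholine, a primary amine or a carboxylic acid there would give a step beyond the scatter. On these data alone, it also remains open whether the same exchange would read alike on the ring attachment seen in compound 2, since that compound differs from compound 3 in more than one place.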